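The source may report more compounds than this note shows. Statements on the series, on what has been measured and on what is new or still open speak of the compounds shown alone.

The measured compounds in a functional assay on HCT-116 cells (Homo sapiens) for inhibition, read by MTT assay, with a stated time of 72 h; on this read-out lower numbers stand for stronger inhibition and higher numbers for weaker inhibition:
compound 1 `O=C(Nc1ccccc1)c1ccc(/N=N\c2c[nH]c3ccccc23)cc1`, 103000 nM
compound 2 `O=C(Nc1ccccc1[N+](=O)[O-])c1ccc(/N=N\c2c[nH]c3ccccc23)cc1`, 208000 nM
compound 3 `COc1ccccc1NC(=O)c1ccc(/N=N\c2c[nH]c3ccccc23)cc1`, 122000 nM

Compound 3 stands second highest of the three numbers; its nearest neighbour is compound 1 and its furthest compound 2, and both gaps lie within the scatter. Compound 4 `O=C(Nc1ccc(Cl)cc1)c1ccc(/N=N\c2c[nH]c3ccccc23)cc1` differs from compound 3 by 4-chlorophenyl in place of 2-methoxyphenyl on an amide-type nitrogen. Going by the values given here, no measured pair involves a 4-chlorophenyl group. Among the compounds with values here, the steps that bear on changes at this nitrogen are a 1.2-fold higher number from compound 1 to compound 3 (0.07 log units; within the scatter), a 2.0-fold higher number from compound 1 to compound 2 (0.31 log units; beyond the scatter) and a 1.7-fold lower number from compound 2 to compound 3 (0.23 log units; within the scatter): one small, one modest, the last within the scatter. A small step in either direction, or none beyond the scatter, is therefore expected in this assay. Compound 4 is estimated to give 110000 nM, with a range from 50000 nM to 250000 nM. That estimate corresponds to an expected step of a 1.1-fold lower number from compound 3 to compound 4 (0.04 log units; within the scatter).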

Compound 4, half-maximal inhibitory concentration: 187000 nM
Beside the measured number, compound 4's estimate is 1.7-fold (0.23 log units) below it, within the range that was stated.
By their numbers in this assay, from the lowest: compounds 1, 3, 4 and 2 (each within the scatter of the next, the first and the last beyond it).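

In this assay the 4-chlorophenyl group on the amide-type nitrogen leaves compound 4 within the scatter of every earlier compound, whether it replaces 2-methoxyphenyl (a 1.5-fold higher number from compound 3 to compound 4 (0.19 log units; within the scatter)) or 2-nitrophenyl (a 1.1-fold lower number from compound 2 to compound 4 (0.05 log units; within the scatter)). Adding a chloro group to compound 1 also stays within the scatter (a 1.8-fold higher number from compound 1 to compound 4 (0.26 log units; within the scatter)), so this change, unlike nitro on compound 1, gives no step beyond it. No measurement shown here explains these small steps.

Going by these compounds, whether an amine, a carboxylic acid or a longer chain on this phenyl ring would give a larger step remains open. So does the effect of any change to the shared core.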